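Replacing the Halogenated Aryl Arm with an Acetoxythiophene

A few compounds are considered here, and "the series" means these few. Any claim that something is new, unique, unknown or untested is made for them only; others in the source may bear on it.

Compound 1, `O=C(Nc1ccc(Oc2ccc(-c3ncc[nH]3)cc2)cc1)Nc1cccc(C(F)(F)F)c1`: 28.1%
Compound 2, `O=C(Nc1ccc(Oc2ccc(-c3ncc[nH]3)cc2)cc1)Nc1cc(C(F)(F)F)ccc1Cl`: 32.3%
Compound 3, `O=C(Nc1ccc(Oc2ccc(-c3ncc[nH]3)cc2)cc1)Nc1cc(Br)cc(C(F)(F)F)c1`: -13.6%

All three compounds share one core and differ only in the aryl group carried on one amide-type nitrogen of the urea. In a functional assay on MDA-MB-231 cells (Homo sapiens) for inhibition, read by MTT assay and WST assay, with a stated time of 72 h, tested at 10 uM (on this read-out higher numbers stand for more inhibition of growth at the one concentration tested and lower numbers for less inhibition of growth), compound 3 gives -13.6%, the lowest of the three numbers, while compound 1 gives 28.1% and compound 2 gives 32.3%. The step of a number 4.2 percentage points higher from compound 1 to compound 2 (within the scatter) shows that a small change on this ring can leave the read-out untouched, whereas a number 41.7 percentage points lower from compound 1 to compound 3 (beyond the scatter) and a number 45.9 percentage points lower from compound 2 to compound 3 (beyond the scatter) show that another small change there can move it a long way.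

Compound 4, `CC(=O)Oc1sccc1NC(=O)Nc1ccc(Oc2ccc(-c3ncc[nH]3)cc2)cc1`, has not yet been measured. It differs from compound 3 in one place: 2-acetoxythiophen-3-yl in place of 3-bromo-5-(trifluoromethyl)phenyl on an amide-type nitrogen. Within the data shown here, no measured step involves a thiophene or an acetoxy group, so the direction of this change cannot be read from the data. What the measured steps do show is that this arm is sensitive: a number 41.7 percentage points lower from compound 1 to compound 3 (beyond the scatter) and a number 45.9 percentage points lower from compound 2 to compound 3 (beyond the scatter) were both large. Because compound 3 gives -13.6%, the lowest number, and the other two compounds sit well above it, a sizeable step is expected, more likely upward than downward, as a number 28.6 percentage points higher from compound 3 to compound 4 (beyond the scatter). Compound 4 is therefore estimated at 15% in this assay, within a range from -15% to 45%.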

Compound 4, percent growth inhibition at one concentration: -1.46%
Estimate against measurement, compound 4: 16.5 percentage points above, and the stated range covers the measured number.
By their numbers in this assay, from the lowest: compound 3; then compound 4; then compounds 1 and 2 (each within the scatter of the next).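

In this assay, the new arm raises the number only modestly, a number 12.1 percentage points higher from compound 3 to compound 4 (beyond the scatter), and it remains well short of the arms with a trifluoromethyl group alone or with a chloro group as well, a number 33.8 percentage points lower from compound 2 to compound 4 (beyond the scatter) and a number 29.6 percentage points lower from compound 1 to compound 4 (beyond the scatter). The low reading on this amide-type nitrogen is therefore not confined to the bromo compound: an arm with no halogen, no trifluoromethyl group and a five-membered ring instead of a six-membered one also falls short of compound 1 and compound 2. No measurement shown here bears on the cause of these differences.

This change replaces the ring and its substituents at once, so the compounds shown cannot separate the effect of the thiophene from that of the acetoxy group; a plain thiophen-3-yl arm, or the same ring carrying a hydroxy or methoxy group, would help to tell them apart. Also open, from the compounds shown here alone, is how a phenyl arm carrying an amine or a carboxylic acid would read in this assay.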